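From Compound 2 to Compound 4: Bromo Exchanged for Chloro

This account rests on a few compounds, and the source may have more. Where it says the series, first, only, none or still open, it means among the compounds named here.

Three compounds sharing one core were examined in an ADME assay on MT4 cells (Homo sapiens) for cytotoxicity, read by MTT assay, with a stated time of 96 h; a lower number here means that less compound is tolerated, a higher number that more compound is tolerated. Compound 1 `Nc1ncnn1/C(S)=N/C1CCCCC1` gives > 100000 nM in this assay, which is a limit of the assay rather than a number. Compound 2 `S=C(Nc1ccc(Br)cc1)Nc1nc[nH]n1` gives > 100000 nM in this assay, again a limit. Compound 3 `O=C(NC(=S)Nc1nc[nH]n1)c1ccccc1` gives > 100000 nM in this assay, also a limit. Where compound 2 stands can therefore be said only so far: its value is a limit, the two other values shown are limits as well, and all three rest at the limit of > 100000 nM in this assay, at which 3 of the 3 values shown sit. Among the measured compounds shown here, no step between measured compounds can be read from values of this kind.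

Compound 4 `S=C(Nc1ccc(Cl)cc1)Nc1nc[nH]n1` has not yet been tested in this assay. It differs from compound 2 by chloro in place of bromo on an aromatic carbon. For the measured compounds named here, with no measured step to lean on, the expectation rests on the three limits alone. Because compound 2 sits at the limit of > 100000 nM in this assay, at which 3 of the 3 values shown sit, the estimated step is a step that the limit leaves unreadable from compound 2 to compound 4, which is none beyond the scatter. In this assay compound 4 is accordingly expected to give 150000 nM, with a range from 60000 nM to 400000 nM, and the result is expected most likely to be reported again only as a limit.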

Compound 4, half-maximal cytotoxic concentration: 47000 nM
Beside the measured number, compound 4's estimate is 3.2-fold (0.50 log units) above it, and the stated range ends above it.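

In this assay, chloro in place of bromo on an aromatic carbon gives an at least 2.1-fold lower number from compound 2 to compound 4 (0.32 log units; beyond the scatter), and this is the only step among the compounds shown that can be read. It shows that this position, on an aromatic carbon of a six-membered aromatic ring of carbon only, para to a group of 9 heavy atoms, responds to the exchange of one halogen for another, although the counts of hydrogen-bond donors and acceptors and the net charge stay the same, and that compound 4 is tolerated less than the limit of compound 2 allows. Compound 2 itself remains a limit, so the step gives only a lower bound on the difference, and the limit is still shared by most of the set: the limit of > 100000 nM in this assay, at which 3 of the 4 values shown sit.

The compounds shown leave open whether the lower number belongs to chloro in particular or would also appear with fluoro, methyl, an amine or a carboxylic acid at the same place. They also leave open how large the true difference between compound 2 and compound 4 is, and no other step can be read from the limits.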